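A Hexyloxy Replacement at the Solubility Limit

The compounds below may be only part of what the source reports. "The series", "measured", "known", "first", "only" and "open" are said of these compounds alone.

Compound 1 `CN(C)CCNc1ccnc2cc(OCc3ccccc3)ccc12` was measured in a physicochemical assay for solubility; a lower number here means a less soluble compound, a higher number a more soluble compound. In that assay compound 1 gives only a limit, > 10000 ug/mL. Compound 2 `CN(C)CCCNc1ccnc2cc(OCc3ccc(F)cc3)ccc12` likewise gives a limit in this assay, > 10000 ug/mL. Compound 3 `CCOc1ccc2c(NCCCN(C)C)ccnc2c1` also gives a limit in this assay, > 10000 ug/mL. Going by the values given here, all three values sit at the limit of > 10000 ug/mL in this assay, at which 3 of the 3 values shown sit, so the one step between compounds that differ in one place, a step that the two limits leave unreadable from compound 2 to compound 3, cannot be read. Compound 4 `CCCCCCOc1ccc2c(NCCN(C)C)ccnc2c1` differs from compound 1 by pentyl in place of phenyl on a saturated chain carbon bound to an oxygen on an aromatic ring. Among the compounds with values here, no measured step bears on this change with a readable size, so no direction can be drawn from the data. The step of an at least 2.0-fold lower number from compound 1 to compound 4 (0.30 log units; that floor lies within the scatter) is therefore expected to be modest and uncertain. Compound 4 is estimated at 5000 ug/mL, with a range from 800 ug/mL to 12000 ug/mL.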

Compound 4, solubility: > 10000 ug/mL
Compound 4: no number, only a limit; the forecaster's own chance of this, stated with the estimate: 50%; middle value at least 2.0-fold (0.30 log units) from the limit.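

In this assay compound 4 gives only a limit, > 10000 ug/mL. Compound 1 also gives only a limit, so the step between the two cannot be read: the limit of > 10000 ug/mL in this assay, at which 4 of the 4 values shown sit. The compounds shown leave open the size of any difference between benzyloxy and hexyloxy in this assay.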